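A few compounds are considered here, and "the series" means these few. Any claim that something is new, unique, unknown or untested is made for them only; others in the source may bear on it.

Measured compounds:
- compound 1 `Cc1ccc(-n2cc(NC(=O)c3ccc(NS(=O)(=O)c4ccccc4)cc3)cn2)cc1`: 10900 nM
- compound 2 `COc1ccc(-n2cc(NC(=O)c3ccc(NS(=O)(=O)c4ccccc4)cc3)cn2)cc1`: 25600 nM

In a functional assay on MCF7 cells (Homo sapiens) for inhibition, read by MTT assay, with a stated time of 48 h (a lower number here means a stronger inhibitor, a higher number a weaker inhibitor), compound 1 gives 10900 nM, the lowest of the two numbers shown. Among the measured compounds shown here, the only neighbour is compound 2, which in this assay gives 25600 nM; the single measured step, a 2.3-fold higher number from compound 1 to compound 2 (0.37 log units; beyond the scatter), comes from methoxy in place of methyl on an aromatic carbon and is modest but beyond the scatter.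

Compound 3 `Cc1ccc(-n2cc(NC(=O)c3ccc(NS(=O)(=O)c4ccc(Cl)cc4)cc3)cn2)cc1` differs from compound 1 by chloro in place of hydrogen on an aromatic carbon; read one bond further out, the phenylsulfonyl becomes (4-chlorophenyl)sulfonyl. For the measured compounds named here, no measured step touches this part of the molecule: the step from compound 1 to compound 2 changes a group on the other aromatic ring, so it offers no direct guide to what the chloro will do here. With nothing in the data pointing to a large effect in either direction, the expected step of a 1.4-fold lower number from compound 1 to compound 3 (0.13 log units; within the scatter) is small and the estimate leans only slightly towards a lower number, within or near the scatter. For compound 3 the estimate in this assay is therefore 8000 nM, with an expected range from 3000 nM to 25000 nM.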

Compound 3, half-maximal inhibitory concentration: 3990 nM
The estimate for compound 3 lay 2.0-fold (0.30 log units) above the measured number, and the stated range covers the measured number.
By their numbers in this assay, from the lowest: compound 3; then compound 1; then compound 2.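

In this assay, the phenylsulfonyl end of the molecule proves responsive to substitution: chloro in place of hydrogen on an aromatic carbon, para to a large group, gives a 2.7-fold lower number from compound 1 to compound 3 (0.44 log units; beyond the scatter). Among the compounds shown here, the only earlier step changed a group on the other aromatic ring and went the opposite way, with a 2.3-fold higher number from compound 1 to compound 2 (0.37 log units; beyond the scatter), so modest changes beyond the scatter have now been seen at both ends of compound 1, in opposite directions. Nothing measured here accounts for the lower number that comes with the added chloro.

The compounds shown leave open whether this step is particular to chloro or would also follow from another group at the same place, such as fluoro, methoxy, an amine or a carboxylic acid. They also leave open whether the 4-chlorophenyl group would bring a similar step on the methoxy-bearing background of compound 2, and so whether changes at the two ends of the molecule add up.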